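From pyridin-4-yl to 4-(trifluoromethyl)phenyl at one carbon

The source may hold more compounds than are shown below. What is called first, only, known or untested is meant among the compounds shown, and "the series" means these compounds.

Compound 1 `COc1cc(/C=C2\C(=O)N(Cc3ccccc3)CCc3ncn(COCc4ccccc4)c32)cc(OC)c1OC` gives 8560 nM
Compound 2 `O=C1/C(=C\c2ccncc2)c2c(ncn2COCc2ccccc2)CCN1Cc1ccccc1` gives 36000 nM

Measured in a functional assay on A549 cells (Homo sapiens) for inhibition, read by MTT assay, with a stated time of 72 h (on this read-out higher numbers stand for weaker inhibition and lower numbers for stronger inhibition), compound 2 has the higher of the two numbers, and compound 1 stands lower. Compound 3 `O=C1/C(=C\c2ccc(C(F)(F)F)cc2)c2c(ncn2COCc2ccccc2)CCN1Cc1ccccc1` differs from compound 2 in one place. The change is 4-(trifluoromethyl)phenyl in place of pyridin-4-yl on a double-bonded chain carbon bound to a double-bonded ring carbon and it puts 4-(trifluoromethyl)phenyl in place of pyridin-4-yl on a double-bonded chain carbon bound to a double-bonded ring carbon. For the measured compounds named here, only one measured step bears on this place. It is a 4.2-fold higher number from compound 1 to compound 2 (0.62 log units; beyond the scatter) and it came with pyridin-4-yl entering for 3,4,5-trimethoxyphenyl. Going by the values given here, with that step of a 4.2-fold higher number from compound 1 to compound 2 (0.62 log units; beyond the scatter) as the only guide, leaving pyridin-4-yl for a ring of carbon only is expected to give a modest step toward a lower number. The estimate means a 2.8-fold lower number from compound 2 to compound 3 (0.44 log units; beyond the scatter) as the expected step. Compound 3 is estimated at 13000 nM within an expected range from 4500 nM to 36000 nM on this evidence.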

Compound 3, half-maximal inhibitory concentration: 52500 nM
Estimate against measurement, compound 3: 4.0-fold (0.61 log units) below, and the stated range ends below it.
By their numbers in this assay, from the lowest: compound 1; then compounds 2 and 3 (each within the scatter of the next).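

In this assay, putting 4-(trifluoromethyl)phenyl at this carbon in place of pyridin-4-yl gives a 1.5-fold higher number from compound 2 to compound 3 (0.16 log units; within the scatter), so a ring of carbon only and a ring with one hetero atom cannot be told apart here. The 3,4,5-trimethoxyphenyl group now stands apart from two different rings, with a 6.1-fold higher number from compound 1 to compound 3 (0.79 log units; beyond the scatter) alongside the earlier 4.2-fold higher number from compound 1 to compound 2 (0.62 log units; beyond the scatter), so the lower number of compound 1 is no longer set against pyridin-4-yl alone. No measurement at hand gives a reason for this result.

Open, as far as these compounds go, is whether a plain phenyl ring, or one with a single methoxy group, would stand with compound 1 or with compounds 2 and 3. Also open, from the compounds shown here alone, is how a phenyl ring carrying an amine or a carboxylic acid would read at this carbon.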